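Modifying the benzylamide side chain of a quinolinone urea

This account rests on a few compounds, and the source may have more. Where it says the series, first, only, none or still open, it means among the compounds named here.

Compound 1, `Cc1ccccc1-c1c(C(=O)N(C)Cc2ccccc2Cl)n(C)c(=O)c2ccccc12`: 19 nM
Compound 2, `Cn1c(COCc2cc(C(F)(F)F)cc(C(F)(F)F)c2)c(-c2ccccc2)c2ccccc2c1=O`: 23 nM
Compound 3, `CCN(Cc1ccccc1)C(=O)Nc1c(-c2ccccc2)c2cc(C)c(C)cc2c(=O)n1C`: 66 nM

All three were tested in an assay on IM-9 cells for binding affinity to Substance-P receptor (Homo sapiens); a lower number here means a stronger inhibitor, a higher number a weaker inhibitor. Among them compound 3 stands highest, with 66 nM. The nearest of the others is compound 2, whose number lies below that of compound 3 by a gap beyond the usual scatter, and compound 1 lies further below still, also beyond the scatter. Compound 3 is therefore the weakest of the three measured compounds in this assay.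

The next compound, compound 4, `Cc1cc(C)cc(CN(C)C(=O)Nc2c(-c3ccccc3)c3cc(C)c(C)cc3c(=O)n2C)c1`, keeps the core of compound 3 and alters only the urea side chain: (3,5-dimethylbenzyl)(methyl)amino in place of benzyl(ethyl)amino on a carbonyl carbon. For the measured compounds named here, no pair of measured compounds differs by exactly this change, so there is no measured step to lean on directly. Still, compound 2, which also carries a benzyl ring bearing two substituents, gives 23 nM, a lower number than compound 3. On that basis a modest move towards stronger binding is expected for compound 4, with the step from compound 3 to compound 4 estimated at a 2.4-fold lower number from compound 3 to compound 4 (0.37 log units; beyond the scatter). Compound 4 is expected to give about 28 nM, within a range of 9 nM to 90 nM.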

Compound 4, half-maximal inhibitory concentration: 28 nM
For compound 4 middle estimate and measured number coincide at the digits printed; measured number inside the range.
By their numbers in this assay, from the lowest: compounds 1, 2 and 4 (each within the scatter of the next); then compound 3.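

In this assay, the urea side chain proves to be a place where an exchange can shift the number: a 2.4-fold lower number from compound 3 to compound 4 (0.37 log units; beyond the scatter), a modest step, yet one beyond the usual scatter. The exchange of benzyl(ethyl)amino for (3,5-dimethylbenzyl)(methyl)amino on a carbonyl carbon alters two things at once, the ethyl becoming a methyl and the plain benzyl gaining two methyl groups, and the step belongs to the exchange as a whole. Neither side chain carries a hydrogen-bond donor, a hydrogen-bond acceptor or a net charge, and nothing at hand says why the number falls.

The compounds shown leave open how the step divides between the two alterations: a urea carrying benzyl(methyl)amino or (3,5-dimethylbenzyl)(ethyl)amino on the same core would separate them. Also open, as far as these compounds go, is how this position responds to groups other than methyl on the benzyl ring, such as methoxy groups, an amine or a carboxylic acid.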